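A few compounds are considered here, and "the series" means these few. Any claim that something is new, unique, unknown or untested is made for them only; others in the source may bear on it.

Three compounds built on one shared core have been examined in an ADME assay on HepG2 cells (Homo sapiens) for inhibition, with a stated time of 48 h; a lower number here means that less compound is needed, a higher number that more compound is needed for the effect. In this assay compound 1 `CC(C(=O)N1CC2CC2C1)N1CCN(S(=O)(=O)c2ccc(C(C)(C)C)cc2)CC1` gives only a limit, > 40000 nM. Compound 2 `CC(C(=O)N1CCC(C)(C)CC1)N1CCN(S(=O)(=O)c2ccc(C(C)(C)C)cc2)CC1` likewise gives only a limit in this assay, > 40000 nM. Compound 3 `CC(C(=O)N1CCN(C)CC1)N1CCN(S(=O)(=O)c2ccc(C(C)(C)C)cc2)CC1` also gives only a limit in this assay, > 40000 nM. The steps among them, a step that the two limits leave unreadable from compound 1 to compound 2, a step that the two limits leave unreadable from compound 1 to compound 3 and a step that the two limits leave unreadable from compound 2 to compound 3, cannot be read in size because of the limit of > 40000 nM in this assay, at which 3 of the 3 values shown sit. Compound 3 thus stands at the limit of this assay, as do both other measured compounds.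

Compound 4 `CC(C(=O)N1Cc2ccccc2C1)N1CCN(S(=O)(=O)c2ccc(C(C)(C)C)cc2)CC1` differs from compound 3 by a group of 9 heavy atoms (8 carbon, 1 nitrogen; one five-membered non-aromatic ring with 1 hetero atom, one six-membered aromatic ring of carbon only) in place of a group of 7 heavy atoms (5 carbon, 2 nitrogen; one six-membered non-aromatic ring with 2 hetero atoms), on a carbonyl carbon. For the measured compounds named here, none of the measured steps bears directly on this change, and all three are unreadable in size. Compound 4 is therefore expected to give a value close to the limit in this assay, estimated at 40000 nM, within 15000 nM to 100000 nM. The step of a number no higher from compound 3 to compound 4 (the limit leaves the size open) that this estimate implies is expected to be none beyond the scatter.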

Compound 4, half-maximal effective concentration: > 40000 nM
Compound 4 was reported as a limit; the forecaster's own chance of this, stated with the estimate: 75%; the middle value lies on the limit itself.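

The steps linking compound 4 to compound 1, compound 2 and compound 3 cannot be read in size, because compound 4 also gives only a limit: the limit of > 40000 nM in this assay, at which 4 of the 4 values shown sit. The compounds shown leave open how far any of the four actually differ in this assay, and whether any group on the carbonyl carbon gives a readable value there.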